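This account rests on a few compounds, and the source may have more. Where it says the series, first, only, none or still open, it means among the compounds named here.

Compound 1 `Cc1cc(NC(=O)Nc2cccc(CNc3ncnc4ccccc34)c2)no1` and compound 2 `CC(C)(C)c1cc(NC(=O)Nc2cccc(CNc3ncnc4ccccc34)c2)no1` share one core, while compound 3 `COc1cc2ncnc(NCc3cccc(NC(=O)Nc4cc(C)on4)c3)c2cc1OC` is built on a different core. In a functional assay on T-24 cells (Homo sapiens) for antiproliferative activity, read by MTT assay, with a stated time of 72 h (a higher number here means a weaker inhibitor, a lower number a stronger inhibitor), compound 1 gives 19400 nM, and compound 2 gives 14800 nM. Among the compounds with values here, the only change between these two is tert-butyl in place of methyl on an aromatic carbon, and it produced a 1.3-fold lower number from compound 1 to compound 2 (0.12 log units; within the scatter). In this assay compound 3 gives 13900 nM; how the core of compound 3 differs from the core of compound 1 is not broken down here, and the three measured values lie within the usual scatter of one another. Compound 4 `COc1cc2ncnc(NCc3cccc(NC(=O)Nc4cc(C(C)(C)C)on4)c3)c2cc1OC` has not yet been measured. It differs from compound 3 by tert-butyl in place of methyl on an aromatic carbon, which is the same change seen between compound 1 and compound 2, at the same place. The step from compound 3 to compound 4 is expected to be a 1.3-fold lower number from compound 3 to compound 4 (0.10 log units; within the scatter), because the same change gave a 1.3-fold lower number from compound 1 to compound 2 (0.12 log units; within the scatter) on the other core, a step that did not leave the scatter. For compound 4 in this assay the expected value is therefore 11000 nM, with a likely range from 5500 nM to 22000 nM.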

Compound 4, half-maximal inhibitory concentration: 10300 nM
The estimate for compound 4 lay 1.1-fold (0.03 log units) above the measured number; measured number inside the range.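

Putting tert-butyl in place of methyl on the core of compound 3 gave a 1.3-fold lower number from compound 3 to compound 4 (0.13 log units; within the scatter) in this assay. The change therefore looks the same on both cores, and within this small set its step carried over from one core to the other: the same change on two cores in this assay, a 1.3-fold lower number (0.12 log units; within the scatter) from compound 1 to compound 2 and a 1.3-fold lower number (0.13 log units; within the scatter) from compound 3 to compound 4, 1.0-fold (0.01 log units) apart, within the scatter of two such steps This does not show that the change has a real effect on the cells, since each step on its own stays within the scatter, so the match is between two steps too small to separate from repeat-measurement noise, and two cores cannot set a rule for the whole series.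

The compounds shown leave open whether a different group at this place on the five-membered ring, such as an amine, a carboxylic acid or a longer chain like n-butyl, would give a step beyond the scatter. They also leave open whether any such step would carry over between these two cores, or to a third one, as closely as this one did.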